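This account rests on a few compounds, and the source may have more. Where it says the series, first, only, none or still open, it means among the compounds named here.

These working notes follow the series in an ADME assay on HeLa cells (Homo sapiens) for cytotoxicity, read by crystal violet staining, with a stated time of 72 h; a lower number here means that less compound is tolerated, a higher number that more compound is tolerated. In this assay, compound 1 `CCOC(=O)c1cc(CCCOc2ccc(-c3noc(C(F)(F)F)n3)cc2OC)on1` reads > 100000 nM, which is a limit of the assay and not a number. Compound 2 `CCOC(=O)c1cc(CCCOc2ccc(-c3noc(C(F)(F)F)n3)cc2[N+](=O)[O-])on1` reads > 100000 nM, which is likewise a limit and not a number. Compound 2 therefore has no number of its own, and the record so far consists of the limit of > 100000 nM in this assay, at which 2 of the 2 values shown sit.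

Among the compounds with values here, the only measured step is a step that the two limits leave unreadable from compound 1 to compound 2, with nitro in place of methoxy on an aromatic carbon. It gives no size to carry forward.

Compound 3 `CCOC(=O)c1cc(CCCOc2ccc(-c3noc(C(F)(F)F)n3)cc2C(F)(F)F)on1` differs from compound 2 at that same aromatic carbon: trifluoromethyl in place of nitro on an aromatic carbon. The change is trifluoromethyl in place of nitro, on a carbon ortho to a large group.

Because compound 2 reads > 100000 nM as a limit, no step beyond the scatter is expected in this assay, and no direction can be favoured. The expected step is a number no higher from compound 2 to compound 3 (the limit leaves the size open).

Compound 3 is expected at 100000 nM, with an estimated range of 40000 nM to 200000 nM, and it may well be reported only as a limit again.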

Compound 3, half-maximal cytotoxic concentration: 28400 nM
Estimate against measurement, compound 3: 3.5-fold (0.55 log units) above; measured number below the stated range.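

In this assay, this aromatic carbon, ortho to a large group, now shows a readable effect on the tolerated concentration: trifluoromethyl in place of nitro gives an at least 3.5-fold lower number from compound 2 to compound 3 (0.54 log units; beyond the scatter), and trifluoromethyl in place of methoxy gives an at least 3.5-fold lower number from compound 1 to compound 3 (0.54 log units; beyond the scatter). Within the data shown here, compound 3 is the only one of the three compounds with a number rather than a limit, so less of it is tolerated, whereas the step between methoxy and nitro cannot be read. Both readable steps give only a minimum size, because each starts from a compound that sits at a limit: the limit of > 100000 nM in this assay, at which 2 of the 3 values shown sit.

The compounds shown leave open whether the lower number is particular to trifluoromethyl or would also appear with an amine, a carboxylic acid or a nitrile on the same carbon. They also leave open how far methoxy and nitro lie apart, and whether trifluoromethyl would give a similar step at another carbon of the six-membered aromatic ring.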